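This account rests on a few compounds, and the source may have more. Where it says the series, first, only, none or still open, it means among the compounds named here.

Measured compounds:
compound 1, `CC(C)(C)OC(=O)NCCS(=O)(=O)NC(=O)c1ccc(Nc2nc(NC3(c4ccc(Cl)cc4)CC3)nc(OCC(F)(F)F)n2)cc1`, 92%
compound 2, `O=C(NS(=O)(=O)C1CC1)c1ccc(Nc2nc(NC3(c4ccc(Cl)cc4)CC3)nc(OCC(F)(F)F)n2)cc1`, 100%
compound 3, `CS(=O)(=O)NC(=O)c1ccc(Nc2nc(NC3(c4ccc(Cl)cc4)CC3)nc(OCC(F)(F)F)n2)cc1`, 100%

In an ADME assay on microsomes from liver (Homo sapiens) for metabolic stability, with a stated time of 10 min (a lower number here means that less of the compound is left, a higher number that more of the compound is left), compound 1 gives 92%. This is the lowest of the three numbers, but only narrowly: a number 8 percentage points higher from compound 1 to compound 2 (within the scatter), and a number 8 percentage points higher from compound 1 to compound 3 (within the scatter). Between the two companions, no change at the digits printed from compound 2 to compound 3 (within the scatter). All three values therefore sit close together near the top of the read-out, and no ordering among them can be claimed.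

Compound 4, `Cc1ccccc1S(=O)(=O)NC(=O)c1ccc(Nc2nc(NC3(c4ccc(Cl)cc4)CC3)nc(OCC(F)(F)F)n2)cc1`, is the next case and differs from compound 1 in a single place: 2-methylphenyl in place of 2-((tert-butoxycarbonyl)amino)ethyl on a sulfonyl sulfur. For the measured compounds named here, the earlier steps are the only guide, and each of them also changed the group on the sulfonyl sulfur. Both the step from compound 1 to compound 2 and that from compound 1 to compound 3 removed the 2-((tert-butoxycarbonyl)amino)ethyl group and moved the number up, yet each stayed within the scatter; the step from compound 2 to compound 3 gave no change at all. The consistent picture is that this position has so far tolerated exchange without a step beyond the scatter, and the same is expected for compound 4, with a number 3 percentage points higher from compound 1 to compound 4 (within the scatter) estimated in this assay.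

For compound 4 the estimate in this assay is 95%, within a range of 82% to 100%.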

Compound 4, percent of the compound remaining: 100%
Compound 4: the middle estimate sits 5 percentage points below what was measured; low and high end bracket the measured number.
By their numbers in this assay, from the lowest: compounds 1, 2, 3 and 4 (each within the scatter of the next).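

In this assay, 2-methylphenyl on the sulfonyl sulfur gives a number 8 percentage points higher from compound 1 to compound 4 (within the scatter), and comparison with the two smaller groups gives no change at the digits printed from compound 3 to compound 4 (within the scatter) and no change at the digits printed from compound 2 to compound 4 (within the scatter). The result extends the range of groups tolerated at this place, on a sulfonyl sulfur whose other neighbour is an amide-type nitrogen: a six-membered aromatic ring of carbon only now stands with the 2-((tert-butoxycarbonyl)amino)ethyl chain, cyclopropyl and methyl, and none of the four compounds goes against the pattern of steps within the scatter. Nothing available here accounts for this outcome at the level of mechanism, so the finding remains a description of the measured values.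

The compounds shown leave open whether a free amine on the ethyl chain, a carboxylic acid at the end of a longer chain or a pyridine ring on the sulfonyl sulfur would also stay within the scatter of these four in this assay. They also leave open whether the same holds once the group on the sulfonyl sulfur is combined with a different group elsewhere on the shared core.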